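Series notes: 4-hydroxy-3-methoxyphenyl in place of phenyl

The source may report more compounds than this note shows. Statements on the series, on what has been measured and on what is new or still open speak of the compounds shown alone.

Two compounds have numbers in a functional assay on the whole organism (strain albino) with Rattus norvegicus as the target, in the maximal electroshock model, with a stated time of 1 h, at a dose of 30 mg/kg by the intraperitoneal route; on this read-out lower numbers stand for less inhibition and higher numbers for more inhibition at the one dose given (going by the name of the read-out). Compound 1 `Cc1nc2ccc(Br)cc2c(=O)n1NCc1nnc(N2C(=O)CSC2c2ccccc2)s1` gives 60%. Compound 2 `Cc1nc2ccccc2c(=O)n1NCc1nnc(N2C(=O)CSC2c2ccccc2)s1` gives 60%. Within the data shown here, the single measured step, no change at the digits printed from compound 1 to compound 2 (within the scatter), is within the scatter, so both compounds stand at one level, and compound 2 is level with compound 1 at the digits reported.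

Compound 3 `COc1cc(C2SCC(=O)N2c2nnc(CNn3c(C)nc4ccccc4c3=O)s2)ccc1O` has not been measured. It differs from compound 2 by 4-hydroxy-3-methoxyphenyl in place of phenyl on a saturated ring carbon. Among the measured compounds shown here, no measured step bears on this change: the one step in hand, no change at the digits printed from compound 1 to compound 2 (within the scatter), concerns hydrogen in place of bromo on an aromatic carbon at the other end of the shared core and shows no change within the scatter, so it says nothing about the saturated ring carbon. For the measured compounds named here, the expectation therefore rests on the level of compound 2 alone, and the range is set wide because a change at this position has no precedent.

Compound 3 is expected to give 55%, with a range from 25% to 85%. The expected step of a number 5 percentage points lower from compound 2 to compound 3 (within the scatter) is none beyond the scatter.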

Compound 3, a percentage reported as inhibition, in the whole organism at one dose (the size of the read-out at that dose, not a potency): 60%
For compound 3 the middle estimate is 5 percentage points below the measured one; measured number inside the range.
By their numbers in this assay, from the lowest: compounds 1, 2 and 3 (each within the scatter of the next).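

In this assay, 4-hydroxy-3-methoxyphenyl in place of phenyl on the saturated ring carbon gives no change at the digits printed from compound 2 to compound 3 (within the scatter) at a site that the earlier step, at the other end of the shared core, did not touch. This position therefore accepts a larger group with more heavy atoms, together with a hydrogen-bond donor and hydrogen-bond acceptors that phenyl does not carry, without any change beyond the scatter in this read-out at the one dose given. Nothing measured here accounts for the level read-out.

On these data alone, whether the level holds with an amine, a carboxylic acid or a longer chain on this carbon remains open, as does the separate part played by the hydroxy and methoxy groups of the entering ring. Also open, as far as these compounds go, is whether 4-hydroxy-3-methoxyphenyl and bromo together on the shared core would give the same level, and single-dose percentages cannot show whether the compounds would separate at other doses.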